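Aryl extension on the core of compound 1

The source may hold more compounds than are shown below. What is called first, only, known or untested is meant among the compounds shown, and "the series" means these compounds.

Compound 1 `O=C(NCCCCc1ccccc1)n1c(=O)oc2ccccc21` is the parent of the pair measured so far. In an assay on HEK293 cells for inhibition of acid ceramidase (Homo sapiens), with a stated time of 10 min (a lower number here means a stronger inhibitor, a higher number a weaker inhibitor), compound 1 gives 64 nM, the higher of the two numbers. For the measured compounds named here, compound 2 `O=C(NCCCCc1ccccc1)n1c(=O)oc2cc(F)ccc21` carries a fluoro in place of hydrogen on an aromatic carbon of the shared core, and in this assay compound 2 gives 31 nM; the step of a 2.1-fold lower number from compound 1 to compound 2 (0.31 log units; beyond the scatter) is the only change recorded. Compound 3 `O=C(NCCCCc1ccccc1)n1c(=O)oc2ccc(-c3ccc(F)cc3)cc21` is not yet measured. It differs from compound 1 by 4-fluorophenyl in place of hydrogen on an aromatic carbon. Going by the values given here, the single recorded step concerns fluoro alone, a far smaller group than 4-fluorophenyl, so it bears only loosely on the present change and gives no firm direction. The expected step in this assay is therefore modest, a 1.4-fold lower number from compound 1 to compound 3 (0.15 log units; within the scatter), with wide uncertainty either way. Compound 3 is estimated at 45 nM, within 12 nM to 180 nM.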

Compound 3, half-maximal inhibitory concentration: 56 nM
Estimate against measurement, compound 3: 1.2-fold (0.09 log units) below; the measured number falls inside the stated range.
By their numbers in this assay, from the lowest: compounds 2, 3 and 1 (each within the scatter of the next, the first and the last beyond it).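

In this assay the change gives a 1.1-fold lower number from compound 1 to compound 3 (0.06 log units; within the scatter) and so leaves the number within the scatter. This aromatic carbon of the shared core therefore accepts 4-fluorophenyl, an entering group of 7 heavy atoms with its own six-membered aromatic ring, while compound 3 stays at 56 nM in this range; the earlier pair covered only a fluoro on a different aromatic carbon. No measurement at hand accounts for so small a step.

Still open, on these data alone, is how much of this result belongs to the fluoro of the added ring and how much to the ring itself, a question that plain phenyl at the same carbon would address. Also open, as far as these compounds go, is whether an amine or a carboxylic acid on the added ring would keep the number in this range.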